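Ester to Acid on a Bis-Benzoyl Core

The source may hold more compounds than are shown below. What is called first, only, known or untested is meant among the compounds shown, and "the series" means these compounds.

Two compounds have measurements: compound 1 `O=C(O)c1ccc2ccc(C(=O)c3ccccc3)c-2cc1` and compound 2 `COC(=O)c1ccc2c(C(=O)c3ccccc3)cc(C(=O)c3ccccc3)c-2cc1`. In an assay on cells for displacement of a labelled ligand from Orexin/Hypocretin receptor type 1 (Homo sapiens), read by scintillation counting, with stated times of 10 min and 90 min, tested at 10 uM (a higher number here means more inhibition at the concentration tested (going by the name of the read-out), a lower number less inhibition), compound 1 gives 11%. In this assay compound 2 gives -10.6%, the lowest of the two numbers; compound 1 lies higher by a gap beyond the usual scatter. Compound 3 `O=C(O)c1ccc2c(C(=O)c3ccccc3)cc(C(=O)c3ccccc3)c-2cc1` differs from compound 2 by hydrogen in place of methyl on an oxygen next to a carbonyl group. Among the compounds with values here, no measured pair shows this change alone, so its effect on the read-out is unknown. The step of a number 12.6 percentage points higher from compound 2 to compound 3 (beyond the scatter) is expected to be small, upward, and within the scatter. Compound 3 is estimated at 2%, between -15% and 20%.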

Compound 3, a percentage reported as inhibition, at one concentration (the size of the read-out at that concentration, not a potency): -10.4%
For compound 3 the middle estimate is 12.4 percentage points above the measured one; the range from low to high includes it.
By their numbers in this assay, from the lowest: compounds 2 and 3 (each within the scatter of the next); then compound 1.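

In this assay, hydrogen in place of methyl on an oxygen next to a carbonyl group gives a number 0.2 percentage points higher from compound 2 to compound 3 (within the scatter), so with both benzoyl groups present the methoxycarbonyl and carboxy forms read alike. Benzoyl in place of hydrogen on an aromatic carbon gives a number 21.4 percentage points lower from compound 1 to compound 3 (beyond the scatter), the only single change here that lies beyond the scatter. No evidence bears on the reason for either step. Going by these compounds, whether an amide or an amine in place of the carboxy group would read differently stays open, as does the effect of a smaller acetyl in place of that benzoyl.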